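Notes on a trifluoromethyl-bearing series: cytotoxicity and an N-methyl analogue

This account rests on a few compounds, and the source may have more. Where it says the series, first, only, none or still open, it means among the compounds named here.

Measured so far:
compound 1 `O=C(CN1CCCCC1)Nc1ccc(-c2nc3cc(C(F)(F)F)ccc3[nH]2)cc1` gives 6000 nM
compound 2 `CC(=O)Nc1ccc(-c2nc3cc(C(F)(F)F)ccc3n2C2CCCCC2)cc1` gives 17000 nM

Both values come from an ADME assay on MDBK cells (Bos taurus) for cytotoxicity, read by MTT assay, with a stated time of 96 h; on this read-out lower numbers stand for higher toxicity in this test and higher numbers for lower toxicity in this test. Compound 1 stands lowest of the two numbers, so it is the more toxic of the pair here; compound 2 sits higher, and the gap between the two lies beyond the scatter. The two compounds differ in more than one place, so no single change can be tied to that gap; only the two values as such are known.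

Compound 3 `Cn1c(-c2ccc(NC(=O)CN3CCCCC3)cc2)nc2cc(C(F)(F)F)ccc21` is not yet measured. It follows from compound 1 by methyl in place of hydrogen on an aromatic nitrogen. For the measured compounds named here, no step between measured compounds isolates this change. The nearest hint is compound 2, which also carries a group on that ring nitrogen and gives the higher number, but it differs elsewhere too, so the hint is weak.

A small rise in the number, probably not beyond the scatter, is expected for compound 3, with a 1.3-fold higher number from compound 1 to compound 3 (0.12 log units; within the scatter) as the estimated step. Compound 3 is estimated at 8000 nM, within 3000 nM to 25000 nM.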

Compound 3, half-maximal cytotoxic concentration: 100000 nM
For compound 3 the middle estimate is 13-fold (1.10 log units) below the measured one; measured number outside the range, above it.
By their numbers in this assay, from the lowest: compound 1; then compound 2; then compound 3.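

In this assay, for the compounds shown here, methyl in place of hydrogen on an aromatic nitrogen gives a 17-fold higher number from compound 1 to compound 3 (1.22 log units; beyond the scatter), a large step beyond the scatter, and this is the first single change that can be read on its own. This nitrogen therefore matters strongly on this read-out: with the rest of compound 1 unchanged, a substituent of 1 heavy atom, with no ring, no hydrogen-bond donors or acceptors and no net charge, shifts the result toward lower toxicity in this test. No measurement shown here accounts for a shift of this size, so the step stands as an observation only.

The compounds shown do not separate the effect of adding the methyl from that of losing the hydrogen on this nitrogen, and one substituent in a single matched pair cannot show how the number changes with the size of the group. Also open, going by these compounds, is whether an ethyl group or a longer chain on this nitrogen would give a similar step, and whether methyl would do the same with a different amine on the side chain.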